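Phenyl for Hexyl on a Carbamate Oxygen

The compounds below may be only part of what the source reports. "The series", "measured", "known", "first", "only" and "open" are said of these compounds alone.

In a functional assay on HTB-54 cells (Homo sapiens) for cytotoxicity, read by MTT assay, with a stated time of 72 h (a lower number here means a stronger inhibitor of growth, a higher number a weaker inhibitor of growth), compound 2, `CCCCCCOC(=O)Nc1ccc([Se]C#N)cc1`, gives 48500 nM and stands alongside compound 1, `CCCCOC(=O)Nc1ccc([Se]C#N)cc1`, which gives 43400 nM, the two numbers lying within the usual scatter of each other. For the measured compounds named here, the only measured step, a 1.1-fold higher number from compound 1 to compound 2 (0.05 log units; within the scatter), lengthened the chain and stayed within the scatter. Compound 3, `N#C[Se]c1ccc(NC(=O)Oc2ccccc2)cc1`, differs from compound 2 by phenyl in place of hexyl on an oxygen next to a carbonyl group. Going by the values given here, no measured step swaps an aromatic ring for a chain here, so the flat chain step is the only guide, and it points to little movement. For compound 3 the estimate is 40000 nM, spanning 15000 nM to 110000 nM, which means an expected step of a 1.2-fold lower number from compound 2 to compound 3 (0.08 log units; within the scatter).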

Compound 3, concentration for total growth inhibition: 50200 nM
Compound 3: the middle estimate sits 1.3-fold (0.10 log units) below what was measured; low and high end bracket the measured number.
By their numbers in this assay, from the lowest: compounds 1, 2 and 3 (each within the scatter of the next).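

In this assay the step of a 1.0-fold higher number from compound 2 to compound 3 (0.01 log units; within the scatter) puts phenyl in place of hexyl on an oxygen next to a carbonyl group, and the step of a 1.2-fold higher number from compound 1 to compound 3 (0.06 log units; within the scatter) puts phenyl in place of butyl there. This position therefore takes a six-membered aromatic ring as well as either chain, and this assay does not tell ring from chain. Nothing measured here gives a reason for this.

The groups shown hold carbon only. On these data alone, whether an amine or a carboxylic acid at this position would move the number beyond the scatter stays open.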